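Shortening the chain on the aromatic nitrogen: compound 4

The source may report more compounds than this note shows. Statements on the series, on what has been measured and on what is new or still open speak of the compounds shown alone.

Compound 3 `CC/C=C\Cn1c(Cc2cc(OC)c(OC)c(OC)c2)nc2c(N)ncnc21` gives 64600 nM in a functional assay on MCF7 cells (Homo sapiens) for antiproliferative activity (on this read-out higher numbers stand for weaker inhibition and lower numbers for stronger inhibition), the largest of the three numbers shown, yet separated from compound 1 `CCCCCn1c(Cc2cc(OC)c(OC)c(OC)c2)nc2c(N)ncnc21`, which gives 61700 nM, only by a 1.0-fold higher number from compound 1 to compound 3 (0.02 log units; within the scatter). Compound 2 `C#CCCCn1c(Cc2cc(OC)c(OC)c(OC)c2)nc2c(N)ncnc21` gives 24000 nM, with a 2.7-fold higher number from compound 2 to compound 3 (0.43 log units; beyond the scatter) and a 2.6-fold lower number from compound 1 to compound 2 (0.41 log units; beyond the scatter). Compound 4 `CCn1c(Cc2cc(OC)c(OC)c(OC)c2)nc2c(N)ncnc21` carries methyl in place of but-1-en-1-yl on a saturated chain carbon bound to an aromatic nitrogen. Going by the values given here, no measured step shortens the chain; the three steps exchange unsaturation at fixed length and move this assay modestly at most, or not beyond the scatter. The step to compound 4 is therefore uncharted, and a shift no larger than the modest ones seen is expected, direction open. For compound 4 the estimate in this assay is 70000 nM (range 25000 nM to 200000 nM). The expected step of a 1.1-fold higher number from compound 3 to compound 4 (0.03 log units; within the scatter) is accordingly small.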

Compound 4, half-maximal inhibitory concentration: 79400 nM
Beside the measured number, compound 4's estimate is 1.1-fold (0.05 log units) below it; measured number inside the range.
By their numbers in this assay, from the lowest: compound 2; then compounds 1, 3 and 4 (each within the scatter of the next).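

In this assay, the shortened ethyl chain of compound 4 stays within the scatter of both the saturated and the alkene chains, with a 1.3-fold higher number from compound 1 to compound 4 (0.11 log units; within the scatter) and a 1.2-fold higher number from compound 3 to compound 4 (0.09 log units; within the scatter). Only the alkyne chain stands apart, with a 3.3-fold higher number from compound 2 to compound 4 (0.52 log units; beyond the scatter), so among these compounds shortening alone moves nothing beyond the scatter and compound 2 is the one exception. Nothing at hand accounts for the position of compound 2.

As far as these compounds go, whether an amine or a carboxylic acid on this chain would shift the number stays open. So does whether a longer chain than that of compound 1 would.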